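A few compounds are considered here, and "the series" means these few. Any claim that something is new, unique, unknown or untested is made for them only; others in the source may bear on it.

Measured compounds:
compound 1, `CN(Cc1cn(CC(O)COC(=O)C2CCCCC2)nn1)CC1CCCCC1`, 18%
compound 2, `CCCCN(CCCC)Cc1cn(CC(O)COC(=O)NCc2ccccc2)nn1`, 42%

In an assay on nucleic acid for inhibition of Nucleic Acid, read by fluorescence, tested at 100 uM (a higher number here means more inhibition at the concentration tested (going by the name of the read-out), a lower number less inhibition), compound 1 gives 18%, the lower of the two numbers recorded; compound 2 gives 42%, a reading beyond the usual scatter of the method. Compound 2 differs from compound 1 in more than one place, so the two values are set side by side without a step being drawn between them.

Compound 3, `CN(Cc1cn(CC(O)COC(=O)c2ccccc2)nn1)CC1CCCCC1`, is not yet measured in this assay. It differs from compound 1 by one change, (phenyl in place of cyclohexyl on a carbonyl carbon), on a carbonyl carbon whose other neighbour is oxygen next to a carbonyl group. Within the data shown here, no measured pair in the set carries this same change, so there is no precedent to lean on. The step of a number 4 percentage points higher from compound 1 to compound 3 (within the scatter) is expected to stay within the scatter, with at most a small rise. For compound 3 the estimate in this assay is 22%, within a range from 6% to 40%.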

Compound 3, a percentage reported as inhibition, at one concentration (the size of the read-out at that concentration, not a potency): 6%
Compound 3: the middle estimate sits 16 percentage points above what was measured; the range from low to high includes it.
By their numbers in this assay, from the lowest: compound 3; then compound 1; then compound 2.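

Phenyl in place of cyclohexyl on a carbonyl carbon gives a number 12 percentage points lower from compound 1 to compound 3 (beyond the scatter) in this assay and so shows that this position is not indifferent to the ring it carries. The two rings match in heavy atoms, and in hydrogen-bond donors and acceptors, so the step appears with those counts unchanged and with only the aromatic ring entering for the non-aromatic one. Nothing on hand accounts for the size or the direction of this step.

Open, going by these compounds, is how a pyridine ring, a tert-butyl group or a longer alkyl chain would read on this carbonyl carbon. Also open, on these data alone, is whether the same change gives a step of similar size on a core carrying the dibutylamine of compound 2.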